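Working notes: aryl group exchange on the shared core

The compounds below may be only part of what the source reports. "The series", "measured", "known", "first", "only" and "open" are said of these compounds alone.

Measured so far in a functional assay on DU-145 cells (Homo sapiens) for antiproliferative activity, read by sulforhodamine B assay; a lower number here means a stronger inhibitor, a higher number a weaker inhibitor:
- compound 1 `CCCCCCCCCCCCCCCCCCNC(=O)[C@H]1CSC(Cc2ccccc2)N1`: 15300 nM
- compound 2 `CCCCCCCCCCCCCCCCCCNC(=O)[C@H]1CSC(c2ccc(N(C)C)cc2)N1`: 5300 nM

In this assay compound 1 gives 15300 nM and compound 2 gives 5300 nM. For the measured compounds named here, putting 4-(dimethylamino)phenyl in place of benzyl on a saturated ring carbon gives a 2.9-fold lower number from compound 1 to compound 2 (0.46 log units; beyond the scatter), so compound 2 holds the lowest of the two numbers, with compound 1 as its only neighbour.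

Compound 3 `CCCCCCCCCCCCCCCCCCNC(=O)[C@H]1CSC(c2ccc(F)cc2)N1` is not yet measured. It differs from compound 2 by fluoro in place of dimethylamino on an aromatic carbon. Going by the values given here, the single measured step, a 2.9-fold lower number from compound 1 to compound 2 (0.46 log units; beyond the scatter), concerns a different exchange at the same saturated ring carbon; no step directly covers dimethylamino against fluoro. The lower number of compound 2 arrived together with the dimethylamino group, and compound 3 no longer carries it, so a modest rise toward compound 1 is expected, though a number within the scatter of compound 2 cannot be ruled out.

For compound 3 the expected step is a 1.6-fold higher number from compound 2 to compound 3 (0.21 log units; within the scatter), giving an estimate of 8500 nM with a range from 3000 nM to 25000 nM.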

Compound 3, half-maximal inhibitory concentration: 5700 nM
Beside the measured number, compound 3's estimate is 1.5-fold (0.17 log units) above it, and the stated range covers the measured number.
By their numbers in this assay, from the lowest: compounds 2 and 3 (each within the scatter of the next); then compound 1.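

In this assay, the two groups at the aromatic carbon cannot be told apart, with a 1.1-fold higher number from compound 2 to compound 3 (0.03 log units; within the scatter), so the number of compound 2 does not depend on the dimethylamino group being present. The step away from benzyl is also seen with 4-fluorophenyl, with a 2.7-fold lower number from compound 1 to compound 3 (0.43 log units; beyond the scatter), so within these three compounds both 4-substituted phenyl groups give lower numbers than benzyl. No measurement on hand gives a reason for this result.

As far as these compounds go, it remains open whether an unsubstituted phenyl, or a carboxylic acid or hydroxyl at the same aromatic carbon, would stay at this level. From the compounds shown here alone, it is also open how far these numbers depend on the long chain on the amide, for example if a shorter chain stood in its place.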